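Butylcarbonyl in place of isobutyl on the shared core

The source may hold more compounds than are shown below. What is called first, only, known or untested is meant among the compounds shown, and "the series" means these compounds.

- compound 1 `CC(C)COc1ccc2oc(/C=C/[S+](C)[O-])cc(=O)c2c1` gives 5000 nM
- compound 2 `Cc1cccc2c(=O)cc(/C=C/[S+](C)[O-])oc12` gives 6800 nM
- compound 3 `COc1cccc2oc(/C=C/[S+](C)[O-])cc(=O)c12` gives > 10000 nM as a limit

In a functional assay on DLD-1 cells (Homo sapiens) for cytotoxicity, with a stated time of 48 h (a lower number here means a stronger inhibitor, a higher number a weaker inhibitor), compound 1 gives 5000 nM and compound 2 gives 6800 nM as two values within the scatter of each other, so neither ranks ahead of the other. Compound 3 at > 10000 nM is a limit and not a number.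

The next compound to be tested in this assay is compound 4 `CCCCC(=O)Oc1ccc2oc(/C=C/[S+](C)[O-])cc(=O)c2c1` which keeps the core of compound 1 and changes one group. Butylcarbonyl stands in place of isobutyl on an oxygen on an aromatic ring, and the counted difference is butylcarbonyl in place of isobutyl on an oxygen on an aromatic ring for this step.

Among the compounds with values here, no two measured compounds differ in one place only, so no measured step gives the size of this change. The expectation therefore starts from compound 1 at 5000 nM and foresees no shift in either direction beyond the scatter. The expected change is a 1.2-fold higher number from compound 1 to compound 4 (0.08 log units; within the scatter) in this estimate. For compound 4 the estimated value is 6000 nM with an expected range from 2200 nM to 14000 nM in this assay once it is measured.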

Compound 4, half-maximal inhibitory concentration: 6700 nM
The estimate for compound 4 lay 1.1-fold (0.05 log units) below the measured number, within the range that was stated.
By their numbers in this assay, from the lowest: compounds 1, 4 and 2 (each within the scatter of the next). At a limit, above all of these: compound 3.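

In this assay, putting butylcarbonyl in place of isobutyl on an oxygen on an aromatic ring gives a 1.3-fold higher number from compound 1 to compound 4 (0.13 log units; within the scatter), the first measured size for a change in one place on the shared core. At this position, then, the isobutoxy group can be exchanged for (butylcarbonyl)oxy, which brings in a longer substituent with a carbonyl and a hydrogen-bond acceptor, and the two compounds still cannot be told apart in this cell read-out. Nothing measured here explains why the two values stay so close.

The compounds shown leave open whether any group on this oxygen can move the number beyond the scatter, such as an amine, a carboxylic acid or a chain much longer than butylcarbonyl. As far as these compounds go, with this single step, it also remains open whether butylcarbonyl and isobutyl would compare in the same way on a core carrying a further change, or whether a plain hydroxyl on this aromatic ring would read differently from both.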